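Aryl swap on the chalcone end of a quinolone hybrid

The source may report more compounds than this note shows. Statements on the series, on what has been measured and on what is new or still open speak of the compounds shown alone.

Three compounds that share one core and differ only in the aryl group on the chalcone chain have been examined in an assay on isolated protein for inhibition of DNA topoisomerase 1 (Homo sapiens), with a stated time of 30 min, tested at 20 uM; on this read-out lower numbers stand for a weaker effect and higher numbers for a stronger effect at the one concentration tested. Compound 1 `O=C(CN1CCN(c2cc3c(cc2F)c(=O)c(C(=O)O)cn3C2CC2)CC1)Nc1ccc(C(=O)/C=C/c2ccccc2Cl)cc1` gives 4.2%. Compound 2 `O=C(CN1CCN(c2cc3c(cc2F)c(=O)c(C(=O)O)cn3C2CC2)CC1)Nc1ccc(C(=O)/C=C/c2ccc(Cl)cc2)cc1` gives 0.4%, and compound 3 `COc1ccc(/C=C/C(=O)c2ccc(NC(=O)CN3CCN(c4cc5c(cc4F)c(=O)c(C(=O)O)cn5C4CC4)CC3)cc2)cc1OC` gives 2.5%. All three numbers sit close together, and compound 1 stands among them with both of its steps to the other two inside the scatter: a number 3.8 percentage points lower from compound 1 to compound 2 (within the scatter) and a number 1.7 percentage points lower from compound 1 to compound 3 (within the scatter), while a number 2.1 percentage points higher from compound 2 to compound 3 (within the scatter).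

Compound 4 `Cc1ccc(/C=C/C(=O)c2ccc(NC(=O)CN3CCN(c4cc5c(cc4F)c(=O)c(C(=O)O)cn5C4CC4)CC3)cc2)c(C)c1` has not yet been measured. It differs from compound 1 as follows: 2,4-dimethylphenyl in place of 2-chlorophenyl on a double-bonded chain carbon bound to a double-bonded chain carbon.

The measured steps that bear on this change are the three aryl replacements on the same chain carbon, none of which moved the read-out beyond the scatter. Chlorine positions and methoxy groups alike left the small inhibition essentially unchanged. Among the measured compounds shown here, no step to a dimethylphenyl group has been measured, so the expectation rests on the three aryl swaps already seen. For compound 4 the expected step is a number 1.2 percentage points lower from compound 1 to compound 4 (within the scatter), that is, no change beyond the scatter. Compound 4 is therefore estimated to give 3% in this assay, with a range from -4% to 10%.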

Compound 4, a percentage reported as inhibition, at one concentration (the size of the read-out at that concentration, not a potency): 11%
Beside the measured number, compound 4's estimate is 8 percentage points below it, outside the stated range (above it).
By their numbers in this assay, from the lowest: compounds 2, 3, 1 and 4 (each within the scatter of the next, the first and the last beyond it).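

In this assay this chain carbon shows its first step beyond the scatter: a number 10.6 percentage points higher from compound 2 to compound 4 (beyond the scatter), a modest step that comes with 2,4-dimethylphenyl in place of 4-chlorophenyl. The same group stays within the scatter against the other two aryl groups, with a number 6.8 percentage points higher from compound 1 to compound 4 (within the scatter) and a number 8.5 percentage points higher from compound 3 to compound 4 (within the scatter), so the change from 2-chlorophenyl to 2,4-dimethylphenyl does not separate its two compounds, and only the two ends of the series stand apart. The position therefore responds to the aryl group only slightly in this series, and no measurement shown gives a reason for the one separated pair.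

Going by these compounds, it stays open whether the two methyl groups are both needed for that separation or whether a phenyl ring with a single methyl group would match compound 4 , and whether an amine or a carboxylic acid on the phenyl ring would carry the read-out further beyond the scatter. On these data alone, it also stays open whether the separation between compound 2 and compound 4 would hold at any concentration other than the one tested.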